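Swapping cyclohexyl for methyl on a dibutylamino sulfone

This account rests on a few compounds, and the source may have more. Where it says the series, first, only, none or still open, it means among the compounds named here.

Measured in a functional assay (aorta) with Rattus norvegicus as the target; on this read-out lower numbers stand for stronger inhibition and higher numbers for weaker inhibition:
Compound 1 `CCN(CC)CCCOc1ccc(S(=O)(=O)c2c(C)cn3ccccc23)cc1`: 3390 nM
Compound 2 `CCCN(CCC)CCCOc1ccc(S(=O)(=O)c2c(C)cn3ccccc23)cc1`: 957 nM
Compound 3 `CCCCN(CCCC)CCCOc1ccc(S(=O)(=O)c2c(C3CCCCC3)cn3ccccc23)cc1`: 4070 nM

Compound 3 lies within the scatter of compound 1 and beyond the scatter above compound 2. Compound 4 `CCCCN(CCCC)CCCOc1ccc(S(=O)(=O)c2c(C)cn3ccccc23)cc1` carries methyl in place of cyclohexyl on an aromatic carbon. Within the data shown here, no measured step makes this exchange. Among the measured compounds shown here, the only step available is a 3.5-fold lower number from compound 1 to compound 2 (0.55 log units; beyond the scatter), a modest change at the amine, so it bears only indirectly. Compound 4 shares its methyl with compound 2, at 957 nM, so a modest step to a lower number is expected in this assay. The expected change is a 5.1-fold lower number from compound 3 to compound 4 (0.71 log units; beyond the scatter). For compound 4 the estimated value is 800 nM, with an expected range of 250 nM to 2500 nM.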

Compound 4, half-maximal inhibitory concentration: 162 nM
Estimate against measurement, compound 4: 4.9-fold (0.69 log units) above, outside the stated range (below it).
By their numbers in this assay, from the lowest: compound 4; then compound 2; then compounds 1 and 3 (each within the scatter of the next).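

In this assay the exchange of cyclohexyl for methyl on the aromatic carbon can now be read directly, and it gives a 25-fold lower number from compound 3 to compound 4 (1.40 log units; beyond the scatter) as a large step. Among these compounds, with methyl kept in place, the amine also matters further than the earlier compounds showed, with a 5.9-fold lower number from compound 2 to compound 4 (0.77 log units; beyond the scatter) and a 21-fold lower number from compound 1 to compound 4 (1.32 log units; beyond the scatter) on moving to dibutylamino. No measurement at hand accounts for either change. From the compounds shown here alone, it remains open whether ethyl or phenyl on this aromatic carbon would stay close to methyl or to cyclohexyl. Going by these compounds, it also remains open whether dipentylamino or piperidine on the chain would extend the amine trend.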